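The compounds below may be only part of what the source reports. "The series", "measured", "known", "first", "only" and "open" are said of these compounds alone.

Measured in an ADME assay on HeLa cells (Homo sapiens) for cytotoxicity, read by ATP content, with a stated time of 3 days; a lower number here means that less compound is tolerated, a higher number that more compound is tolerated:
compound 1 `O=c1n(Cc2cc3cnccc3n2CCCCO)c2cnccc2n1C1CC1` gives only a limit, > 100000 nM
compound 2 `CS(=O)(=O)CCCn1c(Cn2c(=O)n(C3CC3)c3ccncc32)cc2ccccc21` gives only a limit, > 100000 nM
compound 3 `N#CCCCn1c(Cn2c(=O)n(-c3ccc(OC(F)(F)F)cc3)c3ccncc32)cc2cc(Cl)ccc21` gives only a limit, > 50000 nM

Compound 3 sits at the limit of > 50000 nM in this assay, at which 1 of the 3 values shown sits, while the other two members sit at the limit of > 100000 nM in this assay, at which 2 of the 3 values shown sit; none of the three yields a number, so no ordering among them can be read.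

Compound 4 `N#CCCCn1c(Cn2c(=O)n(-c3ncccn3)c3ccncc32)cc2cc(Cl)ccc21` differs from compound 3 by pyrimidin-2-yl in place of 4-(trifluoromethoxy)phenyl on an aromatic nitrogen. Among the measured compounds shown here, no measured step exists for this change. Given that every value of this series is a limit, the expected step in this assay is none beyond the scatter, that is a step that the limit leaves unreadable from compound 3 to compound 4.

Compound 4 is therefore estimated at 100000 nM, with a range from 30000 nM to 300000 nM, and is most likely to come back as a limit again.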

Compound 4, half-maximal cytotoxic concentration: > 50000 nM
Compound 4: a limit, no number; the forecaster's own chance of this, stated with the estimate: 80%; the middle value is on the limit's open side.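

In this assay compound 3 gives > 50000 nM, a limit. Compound 4 gives > 50000 nM, also a limit, so no step can be read between compound 3 and compound 4. The compounds shown leave open whether either substituent changes the tolerated concentration at all.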